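The source may hold more compounds than are shown below. What is called first, only, known or untested is meant among the compounds shown, and "the series" means these compounds.

Working notes on the series. Of the compounds shown here, three built on one shared core have been measured in a functional assay on MCF7 cells (Homo sapiens) for cytotoxicity, read by MTT assay, with a stated time of 24 h; on this read-out higher numbers stand for weaker inhibition and lower numbers for stronger inhibition. Compound 1 `Cn1c(-c2ccc(NC(=O)CSc3nc4ccccc4s3)cc2)nc(-c2ccccc2)c1-c1ccccc1` gives 15.8 ug/mL in this assay. Compound 2 `Cn1c(-c2ccc(NC(=O)CSC3=NCCS3)cc2)nc(-c2ccccc2)c1-c1ccccc1` gives 26.7 ug/mL. Compound 3 `CN1CCN(CC(=O)Nc2ccc(-c3nc(-c4ccccc4)c(-c4ccccc4)n3C)cc2)CC1` gives 76.5 ug/mL, which is the highest of the three numbers, its nearest neighbour being compound 2 and the furthest compound 1. The measured steps are a 1.7-fold higher number from compound 1 to compound 2 (0.23 log units; within the scatter), a 4.8-fold higher number from compound 1 to compound 3 (0.69 log units; beyond the scatter) and a 2.9-fold higher number from compound 2 to compound 3 (0.46 log units; beyond the scatter); every one of them alters the group on the saturated chain carbon bound to the carbonyl carbon, and nothing else.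

Compound 4 `CCN1CCN(CC(=O)Nc2ccc(-c3nc(-c4ccccc4)c(-c4ccccc4)n3C)cc2)CC1` has not been measured. It differs from compound 3 by methyl in place of hydrogen on a saturated chain carbon bound to an amine nitrogen in a ring. Among the compounds with values here, no measured step touches this place, so none of the three bears directly on the change; the only step within the scatter exchanges one ring-bearing group for another at the carbonyl side, which is a different kind of edit. The data give no ground to expect a step beyond the scatter in this assay, and the expected step of a 1.0-fold lower number from compound 3 to compound 4 (0.00 log units; within the scatter) is accordingly a small one. Compound 4 is estimated at 76 ug/mL in this assay, with an expected range from 38 ug/mL to 150 ug/mL.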

Compound 4, half-maximal inhibitory concentration: 80 ug/mL
Beside the measured number, compound 4's estimate is 1.1-fold (0.02 log units) below it; low and high end bracket the measured number.
By their numbers in this assay, from the lowest: compounds 1 and 2 (each within the scatter of the next); then compounds 3 and 4 (each within the scatter of the next).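

Working notes, continued. In this assay, within the data shown here, the exchange of 4-methylpiperazin-1-yl for 4-ethylpiperazin-1-yl gives the first direct reading at this place, with a 1.0-fold higher number from compound 3 to compound 4 (0.02 log units; within the scatter) showing that the added methyl on a saturated chain carbon bound to an amine nitrogen in a ring does not separate the two compounds. The gaps seen earlier on the saturated chain carbon bound to a carbonyl carbon persist with the ethyl-bearing group, as a 3.0-fold higher number from compound 2 to compound 4 (0.48 log units; beyond the scatter) and a 5.1-fold higher number from compound 1 to compound 4 (0.70 log units; beyond the scatter) show, so in this small set the gap at that place is unaffected by the choice of methyl or ethyl. Nothing on hand accounts for any of these steps.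

The compounds shown leave open whether this flat reading extends to a longer chain such as butyl, to benzyl or to hydroxyethyl at the same place, since only methyl and ethyl are read there. They also leave open how morpholin-4-yl or a simple dimethylamino group on the saturated chain carbon bound to a carbonyl carbon would compare with the groups already in the series.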